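Compound 2 to compound 3: a second oxetan-3-yl

The source may report more compounds than this note shows. Statements on the series, on what has been measured and on what is new or still open speak of the compounds shown alone.

In an ADME assay on microsomes from liver (Rattus norvegicus) for metabolic stability, using NADPH, with a stated time of 10 min (a higher number here means that more of the compound is left, a lower number that less of the compound is left), two compounds have been measured so far. Compound 1 `NCCCCN(C[C@H]1Cc2ncccc2CN1)[C@H]1CCCc2cccnc21` gives 64%, and compound 2 `c1cnc2c(c1)CN[C@@H](CN(CCCCNC1COC1)[C@H]1CCCc3cccnc31)C2` gives 27%, the lower of the two numbers.

Compound 3 `c1cnc2c(c1)CN[C@@H](CN(CCCCN(C1COC1)C1COC1)[C@H]1CCCc3cccnc31)C2` repeats the exchange already made once in the series: oxetan-3-yl in place of hydrogen on an amine nitrogen. Oxetan-3-yl takes the place of hydrogen on an amine nitrogen whose other neighbours are a saturated chain carbon and a saturated ring carbon.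

Within the data shown here, only one measured step bears on this change: a number 37 percentage points lower from compound 1 to compound 2 (beyond the scatter), which also placed oxetan-3-yl on an amine nitrogen. That single step started from a different amine nitrogen, so its size need not recur. Compound 2, at 27%, also has too little left for a drop of that size to repeat in full.

A much smaller step is therefore expected, with no firm evidence on its direction and a slight lean downward. The estimated change is a number 7 percentage points lower from compound 2 to compound 3 (within the scatter). In this assay, the estimate for compound 3 is 20%, with an expected range from 6% to 45%.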

Compound 3, percent of the compound remaining: 72%
The estimate for compound 3 lay 52 percentage points below the measured number; measured number above the stated range.
By their numbers in this assay, from the lowest: compound 2; then compounds 1 and 3 (each within the scatter of the next).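

In this assay the exchange of hydrogen for oxetan-3-yl on an amine nitrogen does not carry a fixed direction in this series: the first such exchange gave a number 37 percentage points lower from compound 1 to compound 2 (beyond the scatter) and the second gives a number 45 percentage points higher from compound 2 to compound 3 (beyond the scatter) on the amine nitrogen whose other neighbours are a saturated chain carbon and a saturated ring carbon. The outcome of this exchange therefore depends on which amine nitrogen receives the group, and the earlier single step could not show that. Set against the unsubstituted chain end, the group of 9 heavy atoms with its two four-membered rings gives a number 8 percentage points higher from compound 1 to compound 3 (within the scatter) in the same assay, so the loss seen with compound 2 does not persist in compound 3. Nothing measured here accounts for the reversal.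

Still open, as far as these compounds go, is whether the recovery is specific to oxetan-3-yl or would also appear with another group in the same place, such as a cyclobutyl or a plain methyl on that amine nitrogen. Also open, from the compounds shown here alone, is whether the same end group gives a similar number on a longer chain.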